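The source may report more compounds than this note shows. Statements on the series, on what has been measured and on what is new or still open speak of the compounds shown alone.

Compound 2 `Clc1cc(N2C[C@@H]3CCNC[C@@H]32)cnc1Cl` gives 4110 nM in a functional assay on HEK293 cells for agonist activity at Neuronal acetylcholine receptor; alpha3/beta4 (Homo sapiens), read by FLIPR (on this read-out higher numbers stand for an effect only at larger amounts of compound and lower numbers for an effect already at smaller amounts), and stands at the highest number of the three measured. Compound 1 `Clc1ccc(N2C[C@@H]3CCNC[C@@H]32)cn1` gives 1390 nM in this assay, and compound 3 `Clc1cc(N2C[C@H]3CCNC[C@H]32)cnc1Cl` gives 339 nM. The step of a 3.0-fold higher number from compound 1 to compound 2 (0.47 log units; beyond the scatter) goes with chloro in place of hydrogen on an aromatic carbon. The step of a 12-fold lower number from compound 2 to compound 3 (1.08 log units; beyond the scatter) rests on the fact that compounds 2 and 3 differ only in the configuration as drawn and does not bear on the present change, which keeps the configuration of compound 2. Compound 4 `Cc1cc(N2C[C@@H]3CCNC[C@@H]32)cnc1Cl` is not yet measured; it differs from compound 2 by methyl in place of chloro on an aromatic carbon. Going by the values given here, no measured step exchanges chloro for methyl at this carbon; the nearest guide is the step from compound 1 to compound 2, a modest rise in number on adding the chloro there, so removing that chloro in favour of methyl is expected to move the number modestly back downwards or to leave it within the scatter. For compound 4 the estimated value in this assay is 2500 nM, with an expected range of 800 nM to 8000 nM. This corresponds to an expected step of a 1.6-fold lower number from compound 2 to compound 4 (0.22 log units; within the scatter).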

Compound 4, half-maximal effective concentration: 1910 nM
Beside the measured number, compound 4's estimate is 1.3-fold (0.12 log units) above it, within the range that was stated.
By their numbers in this assay, from the lowest: compound 3; then compounds 1 and 4 (each within the scatter of the next); then compound 2.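

With hydrogen, chloro and methyl now compared at this aromatic carbon, ortho to a chloro group, the exchange of chloro for methyl gives a 2.2-fold lower number from compound 2 to compound 4 (0.33 log units; beyond the scatter). Against hydrogen at the same carbon, methyl gives a 1.4-fold higher number from compound 1 to compound 4 (0.14 log units; within the scatter). The higher number of compound 2 therefore goes with chloro in this set and not with any group of equal heavy-atom count at this carbon, as methyl does not reproduce it.

Nothing in the evidence at hand bears on why chloro and methyl differ at this carbon. Open questions are how ethyl, methoxy or an amine would fare at this carbon, and whether methyl would keep its standing relative to chloro in the mirror-image configuration of compound 3.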